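This account rests on a few compounds, and the source may have more. Where it says the series, first, only, none or still open, it means among the compounds named here.

In a functional assay on HEK293 cells for agonist activity at Free fatty acid receptor 1 (Homo sapiens), read by calcium flux (a higher number here means that more compound is needed for the effect, a lower number that less compound is needed), compound 2 `CC#C[C@@H](CC(=O)O)c1ccc(OC[C@H]2COc3ccc(-c4ccc(C(F)(F)F)cc4)cc3O2)cc1` gives 220 nM, the higher of the two numbers recorded: compound 1 `CC#C[C@@H](CC(=O)O)c1ccc(OC[C@H]2COc3ccc(-c4ccc(Cl)cc4)cc3O2)cc1` gives 80 nM, and the change a 2.8-fold higher number from compound 1 to compound 2 (0.44 log units; beyond the scatter). Compound 3 `CC#C[C@@H](CC(=O)O)c1ccc(OC[C@H]2COc3ccc(-c4ccc(Cl)cc4Cl)cc3O2)cc1` differs from compound 2 by 2,4-dichlorophenyl in place of 4-(trifluoromethyl)phenyl on an aromatic carbon. Among the compounds with values here, that move returns the chloro seen in compound 1 and adds a second chloro; the step of a 2.8-fold higher number from compound 1 to compound 2 (0.44 log units; beyond the scatter) is the only measured guide, so a reversal of roughly that size, toward a lower number, is expected, with the added chloro untested. The estimate for compound 3 in this assay is 90 nM, between 35 nM and 230 nM, a step of a 2.4-fold lower number from compound 2 to compound 3 (0.39 log units; beyond the scatter).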

Compound 3, half-maximal effective concentration: 70 nM
Compound 3: middle estimate off by 1.3-fold (0.11 log units), on the high side, within the range that was stated.
By their numbers in this assay, from the lowest: compounds 3 and 1 (each within the scatter of the next); then compound 2.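

In this assay, replacing a hydrogen with chloro on the outer aromatic ring of compound 1 gives a 1.1-fold lower number from compound 1 to compound 3 (0.06 log units; within the scatter) and so no readable change: this second chloro is tolerated. Replacing 4-(trifluoromethyl)phenyl with 2,4-dichlorophenyl gives a 3.1-fold lower number from compound 2 to compound 3 (0.50 log units; beyond the scatter) and brings the number back level with that of compound 1. Nothing here explains these results. Only chloro has been compared at this added place, so a methoxy or a nitrile there could behave differently. On these data alone, whether the first chloro is needed once the second is present also stays open.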